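A Smaller Substituent on a Weakly Cytotoxic Core

The source may hold more compounds than are shown below. What is called first, only, known or untested is meant among the compounds shown, and "the series" means these compounds.

Compound 1 `O=c1nc(-c2ccccc2)c2cc(-c3ccccc3F)ccc2[nH]1` is the reference point of this comparison. Among the measured compounds shown here, in an ADME assay on L6 cells (Rattus norvegicus) for cytotoxicity, read by fluorescence and resazurin assay, with a stated time of 72 h (a lower number here means that less compound is needed, a higher number that more compound is needed for the effect), compound 1 gives 55800 nM, the only plain number among the three values shown. Compound 2 `Cn1ccc(-c2cccc3[nH]c(=O)nc(-c4ccccc4)c23)n1` returns only a limit of the assay in this assay, > 50000 nM. Compound 3 `N#Cc1ccc(-c2cccc3[nH]c(=O)nc(-c4ccccc4)c23)cc1` likewise returns a limit in this assay, > 50000 nM. For the measured compounds named here, the single step between measured compounds, a step that the two limits leave unreadable from compound 2 to compound 3, therefore cannot be read in size. The change that leads to compound 4 `Cc1ccc2[nH]c(=O)nc(-c3ccccc3)c2c1` is methyl in place of 2-fluorophenyl on an aromatic carbon. Going by the values given here, no measured step carries this change, so none bears on it directly. What the data do show is the limit of > 50000 nM in this assay, at which 2 of the 3 values shown sit, and compound 1 itself sits close to that limit. No step beyond the scatter is expected in this assay in either direction, and the result may well end at the limit again. Compound 4 is therefore expected to give about 60000 nM in this assay. The expected lower end is 20000 nM and the expected upper end 150000 nM. The estimated step implied is a 1.1-fold higher number from compound 1 to compound 4 (0.03 log units; within the scatter).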

Compound 4, half-maximal effective concentration: > 50000 nM
Compound 4 gave a limit, no number (the forecaster's own chance of this, stated with the estimate: 55%); the middle value does not contradict the limit.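

Compound 4 returns only a limit of the assay in this assay, > 50000 nM. Among the compounds shown here, the change from compound 1 to compound 4 therefore yields no step that can be read in size. The compounds shown leave open whether any substituent on the shared core moves the number in this assay at all, as most values rest at one point: the limit of > 50000 nM in this assay, at which 3 of the 4 values shown sit.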